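A few compounds are considered here, and "the series" means these few. Any claim that something is new, unique, unknown or untested is made for them only; others in the source may bear on it.

Compound 1 `Cc1cc(-c2ccccc2)n(Cc2n[nH]c(=S)o2)n1` — in a functional assay on the whole organism (strain albino) for inhibition, with Rattus norvegicus as the target, read by paw edema, with stated times of 3 h and 1 h, at a dose of 100 mg/kg by the oral route (on this read-out lower numbers stand for less inhibition and higher numbers for more inhibition at the one dose given (going by the name of the read-out)), compound 1 gives 48.7%.
Compound 2 `COc1ccc(NC(=S)NNC(=O)Cn2nc(C)cc2C)cc1` — in this assay compound 2 gives 46.4%.

Compound 2 has the lower of the two numbers in this assay, but its nearest neighbour is compound 1, whose number lies only a little higher and within the scatter of repeated measurements, so the two readings cannot be told apart. Within the data shown here, no step between measured compounds that differ in one place is available, so nothing measured here shows how a single change on the aromatic ring moves this read-out.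

Compound 3 `Cc1cc(C)n(CC(=O)NNC(=S)Nc2ccc([N+](=O)[O-])cc2)n1` is the compound still to be tested. It differs from compound 2 in one place: nitro in place of methoxy on an aromatic carbon. The rest of the molecule is the same.

Among the measured compounds shown here, with no measured step to lean on, the expectation for compound 3 rests on compound 2 alone: a step of a number 3.6 percentage points higher from compound 2 to compound 3 (within the scatter) is expected, small and not clearly beyond the scatter, in either direction. Compound 3 is therefore estimated at 50% in this assay, with a range from 35% to 65%.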

Compound 3, a percentage reported as inhibition, in the whole organism at one dose (the size of the read-out at that dose, not a potency): 62.7%
The estimate for compound 3 lay 12.7 percentage points below the measured number; low and high end bracket the measured number.
By their numbers in this assay, from the lowest: compounds 2 and 1 (each within the scatter of the next); then compound 3.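

Among these compounds, the exchange of methoxy for nitro on the aromatic carbon para to a large group gives, in this assay, a number 16.3 percentage points higher from compound 2 to compound 3 (beyond the scatter), and this is the first one-place step in the set. Among the compounds shown here, it shows that this position is not silent: what sits there can shift the inhibition of paw edema at the one dose given by more than repeated measurements would scatter, which the earlier pair of compounds, with no step between them, could not show. The data at hand offer no measurement that accounts for the step, so it stands as an observation about this single exchange and nothing more.

The compounds shown leave open whether the rise belongs to nitro itself or would also appear with another group at the same place, such as an amine, a chlorine atom, a trifluoromethyl group or a plain hydrogen. One step between two compounds gives no trend across groups, and it also leaves open whether the same exchange would move the read-out in the same direction at a different dose or on a different core.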